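Halogenated Benzyl Amide: Expected Potency of Compound 3

This account rests on a few compounds, and the source may have more. Where it says the series, first, only, none or still open, it means among the compounds named here.

Measured compounds:
compound 1: `CC(Oc1cccnc1Nc1cnn(C)c1)c1cccc(C(=O)NCc2ccc(F)cc2)c1` — 43800 nM
compound 2: `COc1cccc(CNC(=O)c2cccc(C(C)Oc3cccnc3Nc3cnn(C)c3)c2)c1` — 49400 nM

In a functional assay on NCI-H3122 cells (Homo sapiens) for antiproliferative activity, read by MTT assay, with a stated time of 48 h (on this read-out lower numbers stand for stronger inhibition and higher numbers for weaker inhibition), compound 1 gives 43800 nM and compound 2 gives 49400 nM. Compound 1 holds the lower of the two numbers, yet the gap is a 1.1-fold higher number from compound 1 to compound 2 (0.05 log units; within the scatter), so the two compounds cannot be told apart. They share one core and differ only in the aromatic ring carried on the saturated chain carbon bound to the amide-type nitrogen.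

Compound 3, `CC(Oc1cccnc1Nc1cnn(C)c1)c1cccc(C(=O)NCc2ccc(Cl)c(C(F)(F)F)c2)c1`, has not been measured. It alters the same position: 4-chloro-3-(trifluoromethyl)phenyl in place of 4-fluorophenyl on a saturated chain carbon bound to an amide-type nitrogen. Among the compounds with values here, the only measured step at this position, a 1.1-fold higher number from compound 1 to compound 2 (0.05 log units; within the scatter), shows that exchanging one substituted phenyl for another left the number within the scatter. Within the data shown here, no measured step involves a chloro or trifluoromethyl group, so the expectation rests on that single comparison. In this assay the expected step is a 1.1-fold lower number from compound 1 to compound 3 (0.04 log units; within the scatter), no larger than the scatter. Compound 3 is expected at 40000 nM, with a range from 12000 nM to 130000 nM.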

Compound 3, half-maximal inhibitory concentration: 50700 nM
Estimate against measurement, compound 3: 1.3-fold (0.10 log units) below, and the stated range covers the measured number.
By their numbers in this assay, from the lowest: compounds 1, 2 and 3 (each within the scatter of the next).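

In this assay, the step of a 1.2-fold higher number from compound 1 to compound 3 (0.06 log units; within the scatter) shows that the position tolerates more than a swap of one small substituent: 4-chloro-3-(trifluoromethyl)phenyl, with 11 heavy atoms against 7 for 4-fluorophenyl, still leaves the number within the scatter. The comparison with the methoxy compound, a 1.0-fold higher number from compound 2 to compound 3 (0.01 log units; within the scatter), reads the same way, so three differently substituted phenyl groups on the saturated chain carbon bound to the amide-type nitrogen now cannot be told apart, where earlier there were only two. No evidence at hand bears on why the number stays level across these changes.

From the compounds shown here alone, all three compounds carry a phenyl ring at this place, so it remains open whether an amine, a carboxylic acid or a longer chain there would give a number outside the scatter. All three also share the same core, which leaves open how this read-out responds to a change anywhere else in the molecule.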